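Cyano for fluoro on the indole of the urea series

The source may report more compounds than this note shows. Statements on the series, on what has been measured and on what is new or still open speak of the compounds shown alone.

Compound 1 `COc1ccc(NC(=O)N2CCC(c3c[nH]c4ccc(F)cc34)CC2)cc1N1CCN(C)CC1` gives 233 nM in an assay on frontal cortex for binding affinity to 5-hydroxytryptamine receptor 1D (Rattus norvegicus), read by radioligand binding; a lower number here means a stronger inhibitor, a higher number a weaker inhibitor. Compound 2 `COc1ccc(NC(=O)N2CCC(c3c[nH]c4cc(F)ccc34)CC2)cc1N1CCN(C)CC1` gives 200 nM, and compound 3 `COc1ccc(NC(=O)N2CCN(CCCCc3c[nH]c4ccc(F)cc34)CC2)cc1N1CCN(C)CC1` gives 367 nM. a 1.2-fold lower number from compound 1 to compound 2 (0.07 log units; within the scatter). The gap between compound 2 and compound 3 is within the scatter as well. Compound 4 `COc1ccc(NC(=O)N2CCC(c3c[nH]c4ccc(C#N)cc34)CC2)cc1N1CCN(C)CC1` differs from compound 2 by 5-cyano-1H-indol-3-yl in place of 6-fluoro-1H-indol-3-yl on a saturated ring carbon. Going by the values given here, the only measured step at this ring, a 1.2-fold lower number from compound 1 to compound 2 (0.07 log units; within the scatter), moved the fluorine and stayed within the scatter; no measured step exchanges fluorine for a nitrile, so the data give no direction for it. The expectation for compound 4 is therefore no step beyond the scatter, a 1.1-fold higher number from compound 2 to compound 4 (0.04 log units; within the scatter). Compound 4 is estimated at 220 nM, range 80 nM to 600 nM.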

Compound 4, half-maximal inhibitory concentration: 400 nM
Beside the measured number, compound 4's estimate is 1.8-fold (0.26 log units) below it, and the stated range covers the measured number.
By their numbers in this assay, from the lowest: compounds 2, 1, 3 and 4 (each within the scatter of the next).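

In this assay the nitrile gives a 2.0-fold higher number from compound 2 to compound 4 (0.30 log units; within the scatter) and a 1.7-fold higher number from compound 1 to compound 4 (0.23 log units; within the scatter) so neither exchange leaves the scatter. The second step is the direct one, cyano in place of fluoro on an aromatic carbon, and it shows that this indole position accepts the nitrile and its added hydrogen-bond acceptor without a step beyond the scatter. No measurement shown accounts for these numbers. Open, as far as these compounds go, is whether a carboxamide or an aminomethyl group in that place would leave the scatter, and whether 5-cyano-1H-indol-3-yl would behave alike on the longer chain of compound 3 .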